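This account rests on a few compounds, and the source may have more. Where it says the series, first, only, none or still open, it means among the compounds named here.

Measured so far: compound 1 `CN(C)C(=O)c1cc2cnc(Nc3ccc(NC(=O)C4(C(=O)Nc5ccc(Br)cc5)CC4)cc3)nc2n1C1CCCC1` gives -6.6%; compound 2 `CN(C)C(=O)c1cc2cnc(Nc3ccc(NC(=O)C4(C(=O)Nc5cccc(C(F)(F)F)c5)CC4)cc3)nc2n1C1CCCC1` gives 15.7%; compound 3 `COC(=O)c1ccc(NC(=O)C2(C(=O)Nc3ccc(Nc4ncc5cc(C(=O)N(C)C)n(C6CCCC6)c5n4)cc3)CC2)cc1` gives 77.1%.

In a functional assay on A549 cells (Homo sapiens) for inhibition, read by CCK-8 assay, with a stated time of 72 h, tested at 1 uM (a higher number here means more inhibition of growth at the concentration tested, a lower number less inhibition of growth), compound 3 stands highest of the three, with a number 61.4 percentage points higher from compound 2 to compound 3 (beyond the scatter) and a number 83.7 percentage points higher from compound 1 to compound 3 (beyond the scatter). Compound 4 `COC(=O)c1cccc(NC(=O)C2(C(=O)Nc3ccc(Nc4ncc5cc(C(=O)N(C)C)n(C6CCCC6)c5n4)cc3)CC2)c1` carries 3-(methoxycarbonyl)phenyl in place of 4-(methoxycarbonyl)phenyl on an amide-type nitrogen. Within the data shown here, no measured step shifts the same group from one position to another; the nearest is a number 22.3 percentage points higher from compound 1 to compound 2 (beyond the scatter), where the group and its position changed together. Both large steps into compound 3 came with changes at this amide-type nitrogen, so the read-out is clearly sensitive there, and the 3-(methoxycarbonyl)phenyl cannot be assumed to hold the value of compound 3. Compound 4 is therefore expected to come in lower, a number 32.1 percentage points lower from compound 3 to compound 4 (beyond the scatter), at an estimated 45% (range 5% to 80%).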

Compound 4, percent growth inhibition at one concentration: 10.5%
Estimate against measurement, compound 4: 34.5 percentage points above; the range from low to high includes it.
By their numbers in this assay, from the lowest: compound 1; then compounds 4 and 2 (each within the scatter of the next); then compound 3.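

Shifting the same group from 4-(methoxycarbonyl)phenyl to 3-(methoxycarbonyl)phenyl on the amide-type nitrogen gives, in this assay, a number 66.6 percentage points lower from compound 3 to compound 4 (beyond the scatter), so where the methoxycarbonyl sits matters here, not just its presence. As 3-(methoxycarbonyl)phenyl it is not separated from the trifluoromethyl analogue, a number 5.2 percentage points lower from compound 2 to compound 4 (within the scatter), and the step from the 4-bromophenyl analogue stays modest, a number 17.1 percentage points higher from compound 1 to compound 4 (beyond the scatter). No evidence at hand accounts for this dependence on position.

Open, from the compounds shown here alone, is whether a carboxylic acid or a primary amide could replace the methoxycarbonyl of compound 3 and keep its value. Also open, going by these compounds, is whether a nitrile would show the same dependence on position.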